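From Trifluoromethoxy to Cyano: One Change, One Expectation

The source may report more compounds than this note shows. Statements on the series, on what has been measured and on what is new or still open speak of the compounds shown alone.

Compound 1, `Cc1n[nH]c(C(=O)O)c1Cc1cccc(-c2cccc(F)c2)c1`: 50%
Compound 2, `Cc1n[nH]c(C(=O)O)c1Cc1cccc(-c2ccc(OC(F)(F)F)cc2)c1`: 34%

Among the compounds with values here, the two compounds measured so far share one core and differ only in a group on a six-membered aromatic ring of carbon only. In an assay on isolated protein for inhibition of 2-Hydroxyacid oxidase 2 (Homo sapiens), tested at 10 uM (a higher number here means a stronger effect of the compound at the concentration tested, a lower number a weaker effect), compound 1 gives 50%, while compound 2 gives 34%. Compound 2 thus stands lowest of the two numbers, and its gap to compound 1 lies beyond the usual scatter of repeated measurements of this kind.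

Compound 3, `Cc1n[nH]c(C(=O)O)c1Cc1cccc(-c2ccc(C#N)cc2)c1`, has not yet been measured. It differs from compound 2 in one place: cyano in place of trifluoromethoxy on an aromatic carbon. Within the data shown here, no pair of measured compounds shows this same exchange, so there is no measured step to lean on; the only guide is that changing this one group between compound 1 and compound 2 moved the number by more than the scatter.

The coming step is expected to stay modest, in either direction, and may well lie within the scatter: a number 6 percentage points higher from compound 2 to compound 3 (within the scatter). Compound 3 is therefore estimated to give 40% in this assay, with a range from 20% to 60%.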

Compound 3, a percentage reported as inhibition, at one concentration (the size of the read-out at that concentration, not a potency): 46%
Compound 3: the middle estimate sits 6 percentage points below what was measured; low and high end bracket the measured number.
By their numbers in this assay, from the lowest: compound 2; then compounds 3 and 1 (each within the scatter of the next).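

In this assay, cyano in place of trifluoromethoxy gives a number 12 percentage points higher from compound 2 to compound 3 (beyond the scatter), so a single group on this aromatic ring, para to a large group, can move the read-out by more than repeat measurements would. Putting 4-cyanophenyl in place of 3-fluorophenyl gives a number 4 percentage points lower from compound 1 to compound 3 (within the scatter), so compound 1 and compound 3 cannot be told apart in this read-out, even though both the group on the ring and its place differ between them. Nothing available gives a reason for either step.

Still open, as far as these compounds go, is whether the read-out here follows the group itself or its place on the ring, a question that a 3-cyanophenyl or a 4-fluorophenyl group on the shared core would help to separate. Also open, from the compounds shown here alone, is how far this position tolerates a quite different kind of group, such as an amine or a carboxylic acid, in the place that cyano now holds.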